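The source may report more compounds than this note shows. Statements on the series, on what has been measured and on what is new or still open speak of the compounds shown alone.

Measured so far in an ADME assay on HEK293 cells (Homo sapiens) for cytotoxicity, read by CCK-8 assay, with a stated time of 4 days; a higher number here means a weaker inhibitor, a lower number a stronger inhibitor:
compound 1 `Oc1ccc(-c2cc(-c3cccc(O)c3)cc(-c3ccc(O)cc3)n2)cc1` gives > 50000 nM;
compound 2 `Oc1ccc(-c2cc(-c3ccccc3O)cc(-c3ccc(O)cc3)n2)cc1` gives 780 nM;
compound 3 `Oc1ccc(-c2cc(-c3ccccc3O)nc(-c3ccccc3O)c2)cc1` gives > 50000 nM.

For compound 1 this value is a limit of the assay, not a number. For compound 3 it is likewise a limit. Among the measured compounds shown here, compound 2 is the one compound with a numerical reading. For the measured compounds named here, the one change measured is 3-hydroxyphenyl in place of 2-hydroxyphenyl on an aromatic carbon, giving an at least 64-fold higher number from compound 2 to compound 1 (1.80 log units; beyond the scatter); the step is open-ended because of the limit of > 50000 nM in this assay, at which 2 of the 3 values shown sit.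

Compound 4 `Oc1ccc(-c2cc(-c3cccc(O)c3)nc(-c3ccccc3O)c2)cc1` awaits measurement. It differs from compound 3 by 3-hydroxyphenyl in place of 2-hydroxyphenyl on an aromatic carbon. How the cores of compound 3 and compound 2 differ is not broken down here. The change is the same kind as that from compound 2 to compound 1, not the same: there the place was meta to two 4-hydroxyphenyl groups and opposite the ring nitrogen, here it is next to the ring nitrogen, meta to a 2-hydroxyphenyl group and meta to a 4-hydroxyphenyl group.

Since compound 3 already sits at the limit and the same kind of change raised the number from compound 2 to compound 1, compound 4 is expected to stay at the limit, so the expected step is a number no higher from compound 3 to compound 4 (the limit leaves the size open). The estimate for compound 4 is 50000 nM, between 20000 nM and 120000 nM.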

Compound 4, half-maximal inhibitory concentration: 7420 nM
Compound 4: middle estimate off by 6.7-fold (0.83 log units), on the high side; the measured number lies below the stated range.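

In this assay, putting 3-hydroxyphenyl in place of 2-hydroxyphenyl gives an at least 6.7-fold lower number from compound 3 to compound 4 (0.82 log units; beyond the scatter), so a swap that raised the number on one core lowered it on the other: the same change on two cores in this assay, an at least 64-fold higher number (1.80 log units; beyond the scatter) from compound 2 to compound 1 and an at least 6.7-fold lower number (0.82 log units; beyond the scatter) from compound 3 to compound 4, at least 430-fold (2.63 log units) apart, beyond the scatter of two such steps. Neither step has a fixed size, since each has one end at a limit of the assay: the limit of > 50000 nM in this assay, at which 2 of the 4 values shown sit. Among the compounds shown here, the result shows that the outcome of this change on one core does not predict its outcome on another, but it rests on only two pairs of compounds and does not show what makes the direction differ.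

The compounds shown leave open whether the two cores would also part ways for a different group in the same place, such as an amine or a carboxylic acid in place of the hydroxyl on the phenyl ring. They also leave open how 4-hydroxyphenyl would behave in that place on either core.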